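This account rests on a few compounds, and the source may have more. Where it says the series, first, only, none or still open, it means among the compounds named here.

Measured so far in an in vitro ADME assay on the whole organism (S9 fraction, liver) for pharmacokinetics, with Mus musculus as the target; on this read-out higher numbers stand for a longer-lived compound and lower numbers for a shorter-lived compound:

Compound 1 `CN(C)CCCOc1ccc(NC(=O)COc2ccc(Cl)cc2C(=O)c2ccccc2)cc1` gives > 2 h
Compound 2 `Cc1ccccc1CNC(=O)COc1ccc(Cl)cc1C(=O)c1ccccc1` gives > 6 h

Neither entry is an exact half-life. Compound 1 gives > 2 h in this assay and this is a limit of the assay, not a number. Compound 2 gives > 6 h in this assay and this too is only a limit, which is all that can be said of where it stands.

The next compound to be tested is compound 3 `O=C(COc1ccc(Cl)cc1C(=O)c1ccccc1)c1cc2ccccc2[nH]1`, which carries 1H-indol-2-yl in place of (2-methylbenzyl)amino on a carbonyl carbon and otherwise matches compound 2. Among the measured compounds shown here, no pair of measured compounds differs in one place, and no measured step sets the size of this one. The expectation therefore rests on compound 2 alone, with its limit of > 6 h as the only anchor. The estimated step of a number no higher from compound 2 to compound 3 (the limit leaves the size open) is expected to stay within the usual scatter, with no direction favoured. Compound 3 is estimated at 6 h (expected range 2 h to 15 h) and may also be reported only as a limit.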

Compound 3, half-life: 3.5 h
Compound 3: the middle estimate sits 1.7-fold (0.23 log units) above what was measured; measured number inside the range.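

In this assay, among the compounds shown here, placing 1H-indol-2-yl in place of (2-methylbenzyl)amino on a carbonyl carbon gives an at least 1.7-fold lower number from compound 2 to compound 3 (0.23 log units; that floor lies within the scatter), the first step that can be read at all. Compound 3 gives 3.5 h, the only exact half-life among the compounds shown, so this position now has a firm reference point, and it was reached with a change whose only counted difference is the added five-membered aromatic ring with 1 hetero atom, since both groups hold one six-membered aromatic ring of carbon only, 1 hydrogen-bond donor and no net charge. The step has a floor and no fixed size because the value of compound 2 is only a limit of the assay: the limit of > 6 h in this assay, at which 1 of the 3 values shown sits.

As far as these compounds go, whether the true drop from the group that leaves to the group that enters goes beyond the usual scatter remains open, as the floor alone cannot settle it. Also open, from the compounds shown here alone, is how a simple amine, a carboxylic acid or a longer chain on this same carbonyl carbon would read against compound 3, and whether such a group would return an exact half-life or another limit.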